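This account rests on a few compounds, and the source may have more. Where it says the series, first, only, none or still open, it means among the compounds named here.

Working notes on the series, cytotoxicity leg.

Compound 3 `COc1ccc(NC(=O)N[C@H]2CC[C@H](Oc3ccc(F)cc3)CC2)cc1` gives in a functional assay on CRL2813 cells (Homo sapiens) for cytotoxicity, read by sulforhodamine B assay, with a stated time of 5 days (a higher number here means a weaker inhibitor, a lower number a stronger inhibitor), only a limit, > 20000 nM, and not a number. Compound 1 `Cc1ccc(NC(=O)N[C@H]2CC[C@H](Oc3ccc(F)cc3)CC2)cc1` likewise reaches only the limit of > 20000 nM in this assay. Within the data shown here, compound 2 `O=C(Nc1ccc(I)cc1)N[C@H]1CC[C@H](Oc2ccc(F)cc2)CC1` is the one member with a measured number, 10200 nM in this assay. The measured steps are small: an at least 1.9-fold lower number from compound 1 to compound 2 (0.29 log units; that floor lies within the scatter), and an at least 1.9-fold higher number from compound 2 to compound 3 (0.29 log units; that floor lies within the scatter), both floored by the limit of > 20000 nM in this assay, at which 2 of the 3 values shown sit; the step that the two limits leave unreadable from compound 1 to compound 3 is not readable.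

Compound 4 `O=C(Nc1ccccc1I)N[C@H]1CC[C@H](Oc2ccc(F)cc2)CC1` differs from compound 3 by 2-iodophenyl in place of 4-methoxyphenyl on an amide-type nitrogen. Among the measured compounds shown here, the only step that bears on it is the entry of iodo, which in compound 2 brought the number down to a measurable value, and the reverse step to compound 3 that returned it to the limit. A 2-iodophenyl was not measured before, so the expectation rests on the iodo of compound 2 alone.

For compound 4 a number near that of compound 2 is expected, 12000 nM (range 4000 nM to 30000 nM), which as a step from the limit means an expected at least 1.6-fold lower number from compound 3 to compound 4 (0.22 log units; that floor lies within the scatter).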

Compound 4, half-maximal inhibitory concentration: > 20000 nM
Compound 4: a limit, no number; the forecaster's own chance of this, stated with the estimate: 40%; at least 1.6-fold (0.22 log units) between middle value and limit.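

In this assay, 2-iodophenyl in place of 4-iodophenyl on the amide-type nitrogen gives an at least 1.9-fold higher number from compound 2 to compound 4 (0.29 log units; that floor lies within the scatter). Compound 4 carries a limit and not a number, so iodo on the phenyl does not by itself yield a measured value in this series, though the floor of this step does not show a real gap from compound 2. The steps linking compound 4 with compound 1 and compound 3 cannot be read because both ends of each are limits: the limit of > 20000 nM in this assay, at which 3 of the 4 values shown sit.

On these data alone, how far compound 4 truly lies from compound 2 remains open. Also open, as far as these compounds go, is whether a bromo, a chloro, an amine or a carboxylic acid in place of the iodo of 4-iodophenyl would give a measured number in this assay.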